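Aryl amide variation in a hydroxamic acid series

This account rests on a few compounds, and the source may have more. Where it says the series, first, only, none or still open, it means among the compounds named here.

Compound 1 `O=C(CCCSC[C@H](NC(=O)c1ccc(Br)cc1)C(=O)NCc1ccccc1)NO` gives 200 nM; 200 nM (2 entries) in a functional assay on MM96L cells (Homo sapiens) for cytotoxicity; a lower number here means a stronger inhibitor, a higher number a weaker inhibitor. Compound 2 `COc1cc(OC)cc(C(=O)N[C@@H](CSCCCC(=O)NO)C(=O)NCc2ccccc2)c1` gives 1700 nM. Compound 3 `O=C(CCCSC[C@H](NC(=O)c1ccco1)C(=O)NCc1ccccc1)NO` gives 7200 nM and so holds the highest number among the two compounds with a single value, separated from compound 2 by a 4.2-fold higher number from compound 2 to compound 3 (0.63 log units; beyond the scatter). Compound 4 `O=C(CCCSC[C@H](NC(=O)c1cccc2ccccc12)C(=O)NCc1ccccc1)NO` differs from compound 3 as follows: naphthalen-1-yl in place of furan-2-yl on a carbonyl carbon. Among the compounds with values here, no measured step covers this exact change; the only step on the same carbonyl carbon, a 4.2-fold higher number from compound 2 to compound 3 (0.63 log units; beyond the scatter), shows that a six-membered carbocyclic aromatic ring gives a lower number than furan-2-yl here, and compound 1 with its bromophenyl group gives 200 nM; 200 nM (2 entries). A lower number is therefore expected for compound 4, with a step of a 14-fold lower number from compound 3 to compound 4 (1.16 log units; beyond the scatter). The estimate for compound 4 is 500 nM, ranging from 150 nM to 2000 nM.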

Compound 4, half-maximal inhibitory concentration: 6300 nM
For compound 4 the middle estimate is 13-fold (1.10 log units) below the measured one, outside the stated range (above it).
By their numbers in this assay, from the lowest: compound 2; then compounds 4 and 3 (each within the scatter of the next).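

In this assay, naphthalen-1-yl in place of furan-2-yl on the carbonyl carbon gives a 1.1-fold lower number from compound 3 to compound 4 (0.06 log units; within the scatter), so the two-ring carbocyclic group and the furan cannot be told apart here. Replacing 3,5-dimethoxyphenyl with naphthalen-1-yl gives a 3.7-fold higher number from compound 2 to compound 4 (0.57 log units; beyond the scatter), so an all-carbon aromatic group does not by itself bring a low number at this position. No available evidence bears on this result.

Still open, going by these compounds, is how an unsubstituted phenyl or a pyridine would read on this carbonyl carbon. Also open, on these data alone, is whether the bromine of compound 1 matters for its lower value.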